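This account rests on a few compounds, and the source may have more. Where it says the series, first, only, none or still open, it means among the compounds named here.

Within the data shown here, in a physicochemical assay for lipophilicity, measured as octanol-water partition (a lower number here means a more polar compound, a higher number a more lipophilic compound), three compounds on a shared core have numbers so far. Compound 1 (`O=C(COc1cccc2ccccc12)N/N=C/c1ccc(Cl)cc1`) stands at 4.54 and compound 2 (`O=C(COc1cccc2ccccc12)N/N=C/c1ccccc1Br`) at 4.81, while compound 3 (`O=C(COc1cccc2ccccc12)N/N=C/c1cccc([N+](=O)[O-])c1`) stands at 3.97 as the lowest of the three, with both gaps beyond the scatter. Compound 4 (`O=C(COc1cccc2ccccc12)N/N=C/c1cccc(Cl)c1`) differs from compound 3 by one change (chloro in place of nitro on an aromatic carbon): chloro in place of nitro on an aromatic carbon. Among the measured compounds shown here, no measured step replaces nitro with anything, so the evidence is indirect. For the measured compounds named here, the only step available (a number 0.27 log units higher from compound 1 to compound 2 (within the scatter)) exchanges one halogen-bearing group for another and stays within the scatter, though it is a single pair. Compound 1 also carries chloro, and its value (4.54) is the closest guide to what compound 4 should show. In this assay a rise beyond the scatter is therefore expected (a number 0.58 log units higher from compound 3 to compound 4 (beyond the scatter)) for this change. Compound 4 is estimated at 4.55 with an expected range from 4.25 to 4.85 for the measurement.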

Compound 4, partition coefficient: 4.54
The estimate for compound 4 lay 0.01 log units above the measured number, and the stated range covers the measured number.
By their numbers in this assay, from the lowest: compound 3; then compounds 1, 4 and 2 (each within the scatter of the next).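

In this assay, the exchange of nitro for chloro on an aromatic carbon, meta to a large group, now stands as a one-place step: a number 0.57 log units higher from compound 3 to compound 4 (beyond the scatter). The three halogen-bearing compounds do not separate: the 3-chlorophenyl group in place of 4-chlorophenyl gives no change at the digits printed from compound 1 to compound 4 (within the scatter), and in place of 2-bromophenyl it gives a number 0.27 log units lower from compound 2 to compound 4 (within the scatter), so across compounds 1, 2 and 4 neither the halogen nor its place shifts the number beyond the scatter. Nothing at hand explains the size of the step from nitro to chloro.

Among these compounds, compound 3 is the only compound carrying nitro, so it remains open whether the step would be the same elsewhere on the ring. As far as these compounds go, it also remains open where an amine, a carboxylic acid or a methoxy group in this place would stand.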